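Trimming One Carbon from the Chain of Compound 1

The source may report more compounds than this note shows. Statements on the series, on what has been measured and on what is new or still open speak of the compounds shown alone.

Measured so far in a functional assay for inhibition, with Rattus norvegicus as the target; on this read-out lower numbers stand for stronger inhibition and higher numbers for weaker inhibition:
compound 1 `CCCC(/N=C(\S)NCc1ccc(C(C)(C)C)cc1)c1ccc(NS(C)(=O)=O)cc1` gives 1490 nM
compound 2 `C[C@@H](/N=C(\S)NCc1ccc(C(C)(C)C)cc1)c1ccc([N+](=O)[O-])cc1` gives 580 nM
compound 3 `CC(=O)Nc1ccc([C@@H](C)/N=C(\S)NCc2ccc(C(C)(C)C)cc2)cc1` gives 3600 nM

Among these three numbers, compound 1 stands second highest: compound 2 sits below it and compound 3 above it, both beyond the scatter. Compound 4 `CCC(/N=C(\S)NCc1ccc(C(C)(C)C)cc1)c1ccc(NS(C)(=O)=O)cc1` differs from compound 1 only on the chain: hydrogen in place of methyl on a saturated chain carbon, three bonds along the chain from an aromatic carbon and a double-bonded nitrogen. Within the data shown here, the single step recorded so far, a 6.2-fold higher number from compound 2 to compound 3 (0.79 log units; beyond the scatter), concerns a group on the aromatic ring, not the chain, so no measured step bears on this change. With nothing in the data pointing either way, compound 4 is expected to stay close to compound 1 in this assay, with a 1.0-fold higher number from compound 1 to compound 4 (0.00 log units; within the scatter) and no movement beyond the scatter. The estimate for compound 4 is 1500 nM, with a range from 600 nM to 3800 nM.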

Compound 4, half-maximal inhibitory concentration: 360 nM
Compound 4: middle estimate off by 4.2-fold (0.62 log units), on the high side; the whole stated range lies above it.
By their numbers in this assay, from the lowest: compounds 4 and 2 (each within the scatter of the next); then compound 1; then compound 3.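

Going from the propyl chain to the ethyl chain gives, in this assay, a 4.1-fold lower number from compound 1 to compound 4 (0.62 log units; beyond the scatter). This is the first step shown on the chain rather than on the aromatic ring, and it shows that the number responds to the chain's length at this carbon, with the shorter chain giving stronger inhibition here. Nothing available explains this shift. Still open, going by these compounds, is what a butyl or cyclopropyl group on this carbon would give. Also open, on these data alone, is whether the same trimming would lower the number with an acetamido or nitro group on the ring.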